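Adding a methoxy to a series at the assay limit

The compounds below may be only part of what the source reports. "The series", "measured", "known", "first", "only" and "open" are said of these compounds alone.

Compound 1 `COc1ccc(CNc2ncnc3c2ncn3C2CCCCO2)cc1OC` gives > 100000 nM in an ADME assay on MCF7 cells (Homo sapiens) for cytotoxicity, with a stated time of 72 h (on this read-out higher numbers stand for weaker inhibition and lower numbers for stronger inhibition), and this value is a limit. Compound 2 `COc1ccc(CNc2ncnc3c2ncn3C2CCCO2)cc1` gives > 100000 nM in this assay, also a limit, so it has no number of its own. Among the compounds with values here, the series so far stands at the limit of > 100000 nM in this assay, at which 2 of the 2 values shown sit. Compound 3 `COc1ccc(CNc2ncnc3c2ncn3C2CCCO2)cc1OC` differs from compound 2 by methoxy in place of hydrogen on an aromatic carbon, ortho to a methoxy group. Within the data shown here, no measured step is available as a guide. A step of a number no higher from compound 2 to compound 3 (the limit leaves the size open) is expected, none beyond the scatter in this assay. Compound 3 is estimated at 100000 nM, with an expected range of 40000 nM to 200000 nM, and will most likely be reported as a limit again.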

Compound 3, half-maximal inhibitory concentration: > 100000 nM
Compound 3: no number, only a limit (the forecaster's own chance of this, stated with the estimate: 85%); the middle value lies on the limit itself.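

Compound 3 gives a limit again, as do compound 1 and compound 2, so no step among these compounds can be read: the limit of > 100000 nM in this assay, at which 3 of the 3 values shown sit.

The compounds shown leave open which structural change, if any, would give a measured number rather than a limit.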